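A Hydroxypentyl Chain Replaces the Trifluoromethylphenyl Group

A few compounds are considered here, and "the series" means these few. Any claim that something is new, unique, unknown or untested is made for them only; others in the source may bear on it.

Compound 3 `COc1nc2ccc(Br)cc2cc1C(c1ccccc1)n1cc(-c2ccccc2C(F)(F)F)nn1` gives the highest of the three numbers shown in an ADME assay on PC-3 cells (Homo sapiens) for cytotoxicity, read by sulforhodamine B assay, with a stated time of 48 h, tested at 10 uM (on this read-out lower numbers stand for less inhibition and higher numbers for more inhibition at the one concentration tested (going by the name of the read-out)), at 17.4%, although its gap to compound 2 is within the scatter. Compound 1 `CCCCCCc1cn(C(c2ccccc2)c2cc3cc(Br)ccc3nc2OC)nn1` gives 2.32% and compound 2 `CCCc1cn(C(c2ccccc2)c2cc3cc(Br)ccc3nc2OC)nn1` gives 8.3%. The step of a number 15.1 percentage points higher from compound 1 to compound 3 (beyond the scatter) lies beyond the scatter, whereas a number 9.1 percentage points higher from compound 2 to compound 3 (within the scatter) lies within it. Compound 4 `COc1nc2ccc(Br)cc2cc1C(c1ccccc1)n1cc(CCCCCO)nn1` differs from compound 3 in one place: 5-hydroxypentyl in place of 2-(trifluoromethyl)phenyl on an aromatic carbon. Both measured steps that bear on this change swap a chain on that aromatic carbon for the 2-(trifluoromethyl)phenyl group, and compound 4 returns to a chain, now carrying one oxygen. A downward step is therefore expected, a number 11.4 percentage points lower from compound 3 to compound 4 (beyond the scatter). Compound 4 is estimated at 6%, with a likely range from 0% to 16%.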

Compound 4, a percentage reported as inhibition, at one concentration (the size of the read-out at that concentration, not a potency): 12.9%
Compound 4: middle estimate off by 6.9 percentage points, on the low side; low and high end bracket the measured number.
By their numbers in this assay, from the lowest: compounds 1, 2, 4 and 3 (each within the scatter of the next, the first and the last beyond it).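

In this assay the 5-hydroxypentyl chain gives a number 4.5 percentage points lower from compound 3 to compound 4 (within the scatter) and so does not clearly fall away from the 2-(trifluoromethyl)phenyl group at this aromatic carbon. Adding the hydroxy-bearing extension to the propyl chain gives a number 4.6 percentage points higher from compound 2 to compound 4 (within the scatter) while the hydroxy in place of the end methyl of the hexyl chain gives a number 10.6 percentage points higher from compound 1 to compound 4 (beyond the scatter) and so this single oxygen separates compound 4 from the hexyl compound. No measurement shown here explains these steps.

On these data alone, whether an amine or a carboxylic acid in place of the hydroxy would behave alike remains open. So does the outcome for a longer hydroxy-bearing chain.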